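The source may hold more compounds than are shown below. What is called first, only, known or untested is meant among the compounds shown, and "the series" means these compounds.

In a functional assay on Ramos cells (Homo sapiens) for antiproliferative activity, read by CCK-8 assay, with a stated time of 24 h (a higher number here means a weaker inhibitor, a lower number a stronger inhibitor), compound 1 `C=CC(=O)Nc1cccc(Nc2ncnc(Nc3ccc(-c4cccnc4)cc3)n2)c1` gives only a limit, > 100000 nM, not a number. That limit is the one described in the limit of > 100000 nM in this assay, at which 1 of the 3 values shown sits, so compound 1 stands at the top of the range covered by the compounds measured here. Compound 2 `C=CC(=O)Nc1cccc(Nc2nc(Cl)nc(Nc3ccc(OCCOC)cc3)n2)c1`, which carries a chloro on the shared core and a methoxyethoxy-substituted aryl amine, has no result recorded in this assay, "not determined" (no result reported). Compound 3 `CC#CC(=O)Nc1cccc(Nc2ncnc(Nc3ccc(C(=O)N4CCCCC4)cc3)n2)c1`, with a but-2-ynamide in place of the acrylamide and a piperidine-carbonyl on the aryl amine, gives a measured value of 24400 nM in this assay; it differs from compound 1 in more than one place, so the two values are only set side by side. Compound 4 `C=CC(=O)Nc1cccc(Nc2ncnc(Nc3ccc(-c4ccc(F)nc4)cc3)n2)c1` differs from compound 1 in a single place: fluoro in place of hydrogen on an aromatic carbon. Among the measured compounds shown here, no measured pair shows the effect of this change, and a single fluorine is a small addition to a compound already at the limit, so no shift beyond the usual scatter is expected; the step from compound 1 to compound 4 is estimated at a number no higher from compound 1 to compound 4 (the limit leaves the size open) in this assay. For compound 4 the expected value in this assay is therefore 100000 nM, within a range from 30000 nM to 300000 nM.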

Compound 4, half-maximal inhibitory concentration: 59200 nM
For compound 4 the middle estimate is 1.7-fold (0.23 log units) above the measured one; low and high end bracket the measured number.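

In this assay, the change from pyridin-3-yl to 6-fluoropyridin-3-yl gives an at least 1.6-fold lower number from compound 1 to compound 4 (0.22 log units; that floor lies within the scatter). This is the first pair shown that differs in one place, and it ties a fluoro on an aromatic carbon next to the ring nitrogen, para to a large group, to a value that can be read as a number. Compound 1 gives a limit and not a number, so the step is only a floor and its true size stays open: the limit of > 100000 nM in this assay, at which 1 of the 4 values shown sits.

The compounds shown leave open whether another group on this same carbon, such as chloro, methoxy or an amine, would give a number different from that of compound 4. They also do not show the step from hydrogen to fluoro on a parent compound that has a measured number rather than a limit.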